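This account rests on a few compounds, and the source may have more. Where it says the series, first, only, none or still open, it means among the compounds named here.

Of the compounds shown here, three of a shared core have been measured in an assay on membranes from HEK293 cells for displacement of a labelled ligand from adenosine receptor A2b (Homo sapiens), read by scintillation counting, with a stated time of 30 min; on this read-out lower numbers stand for stronger inhibition and higher numbers for weaker inhibition. Compound 1 `CCCOC(=O)C1=C(C)NC(=O)NC1c1ccsc1` gives 201 nM, compound 3 `CC1=C(C(=O)CC(C)C)C(c2ccsc2)NC(=O)N1` gives 1000 nM, and compound 2 `CCCC(=O)C1=C(C)NC(=O)NC1c1ccco1` gives 807 nM, the second highest of the three numbers, close to compound 3 and clearly above compound 1. Compound 4 `CC1=C(C(=O)OCC2CCC2)C(c2ccco2)NC(=O)N1` differs from compound 2 by cyclobutylmethoxy in place of propyl on a carbonyl carbon. Within the data shown here, the one measured step that bears on this is the opposite kind of exchange, an ester made into a ketone, which gave a 5.0-fold higher number from compound 1 to compound 3 (0.70 log units; beyond the scatter). Turning the ketone of compound 2 back into an ester is therefore expected to lower the number by a similar amount, about a 4.0-fold lower number from compound 2 to compound 4 (0.61 log units; beyond the scatter). Compound 4 is estimated at 200 nM, within 80 nM to 500 nM.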

Compound 4, inhibition constant: 561 nM
Estimate against measurement, compound 4: 2.8-fold (0.45 log units) below; measured number outside the range, above it.
By their numbers in this assay, from the lowest: compound 1; then compounds 4, 2 and 3 (each within the scatter of the next).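

On this carbonyl carbon, cyclobutylmethoxy in place of propyl gives a 1.4-fold lower number from compound 2 to compound 4 (0.16 log units; within the scatter), so the two numbers cannot be told apart. The exchange between ester and ketone in compounds 1 and 3 gave a 5.0-fold higher number from compound 1 to compound 3 (0.70 log units; beyond the scatter), whereas here an ester and a ketone stand level even though the ester side chain carries a four-membered ring. The size of that earlier step therefore does not carry over to every such pair on the shared core.

Going by these compounds, whether an amine or a carboxylic acid on this carbonyl carbon would keep the number level remains open. Nothing given here accounts for this result.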